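This account rests on a few compounds, and the source may have more. Where it says the series, first, only, none or still open, it means among the compounds named here.

For the measured compounds named here, the series rests on a shared core carrying a sulfonyl-linked phenyl ring, and the three measured members differ at the end of that ring and within the core itself. Compound 1, `N#Cc1ccc(S(=O)(=O)N2C/C(=C\c3ccncc3)C(=O)/C(=C/c3ccccc3F)C2)cc1`, is measured in a functional assay on HepG2 cells (Homo sapiens) for cytotoxicity, read by MTT assay, with a stated time of 24 h (on this read-out lower numbers stand for stronger inhibition and higher numbers for weaker inhibition), and gives 4500 nM. Compound 2, `CC(=O)Nc1ccc(S(=O)(=O)N2C/C(=C\c3ccncc3)C(=O)/C(=C/c3ccccc3F)C2)cc1`, gives 11700 nM in this assay. The two are joined by a single change, (acetamido in place of cyano on an aromatic carbon), and the measured step is a 2.6-fold higher number from compound 1 to compound 2 (0.41 log units; beyond the scatter).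

Compound 3, `N#Cc1ccc(S(=O)(=O)N2C/C(=C\c3cccnc3)C(=O)/C(=C/c3ccccc3C(F)(F)F)C2)cc1`, gives 5060 nM in this assay. Compared with compound 1, the two values sit within the scatter of each other, while against compound 2 the number for compound 3 is the lower one by a margin beyond the scatter. How the core of compound 3 differs from the core of compound 1 is not broken down here.

Compound 4, `CC(=O)Nc1ccc(S(=O)(=O)N2C/C(=C\c3cccnc3)C(=O)/C(=C/c3ccccc3C(F)(F)F)C2)cc1`, has not yet been measured. It differs from compound 3 by acetamido in place of cyano on an aromatic carbon, the same change that separates compound 1 from compound 2, at a place described in the same words. Only one earlier instance of this change exists among these compounds, so the expectation leans entirely on it. Because of a 2.6-fold higher number from compound 1 to compound 2 (0.41 log units; beyond the scatter), the step from compound 3 to compound 4 is expected to be about a 2.6-fold higher number from compound 3 to compound 4 (0.41 log units; beyond the scatter). Compound 4 is therefore estimated at 13000 nM in this assay, with an expected range from 6500 nM to 26000 nM.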

Compound 4, half-maximal inhibitory concentration: 4330 nM
For compound 4 the middle estimate is 3.0-fold (0.48 log units) above the measured one; measured number outside the range, below it.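

In this assay, acetamido in place of cyano on the second core gives a 1.2-fold lower number from compound 3 to compound 4 (0.07 log units; within the scatter), a step that stays within the scatter, so on this core the exchange has no effect that can be told from repeated measurement. Set beside the earlier step, the exchange does not carry over from one core to the other at the same size, so the step seen on the first core cannot simply be transferred to the second: the same change on two cores in this assay, a 2.6-fold higher number (0.41 log units; beyond the scatter) from compound 1 to compound 2 and a 1.2-fold lower number (0.07 log units; within the scatter) from compound 3 to compound 4, 3.0-fold (0.48 log units) apart, beyond the scatter of two such steps. This does not show which feature of the two cores matters, as the core of compound 1 and the core of compound 3 differ in more than one place and the two pairs cannot separate those differences, nor do two pairs say how the exchange would behave on any further core.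

The compounds shown leave open whether a core carrying only one of those differences would behave like the core of compound 1 or like the core of compound 3. They also leave open how other groups at the same place on the aromatic ring, such as an amine, a carboxylic acid or a longer acyl chain, would fare on either core.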